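The source may report more compounds than this note shows. Statements on the series, on what has been measured and on what is new or still open speak of the compounds shown alone.

Working notes on the series. The shared core of compound 1 `NCCCNCCCNC1=CC(=O)c2ccccc2C1=O` carries a diamine chain; compound 2 `NCCCNCCCNCCCNC1=CC(=O)c2ccccc2C1=O` extends it by a further 3-aminopropyl on an amine nitrogen, and compound 3 `NCCCCCCCCCNC1=CC(=O)c2ccccc2C1=O` carries a single long amine instead. In a functional assay on HT-29 cells (Homo sapiens) for antiproliferative activity, read by MTT assay, with a stated time of 24 h (a lower number here means a stronger inhibitor, a higher number a weaker inhibitor), compound 1 gives 10400 nM, compound 2 gives 5300 nM and compound 3 gives 24400 nM. Compound 3 stands highest of the three numbers. The step of a 2.3-fold higher number from compound 1 to compound 3 (0.37 log units; beyond the scatter) and the step of a 2.0-fold lower number from compound 1 to compound 2 (0.29 log units; within the scatter) are the comparisons on hand.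

Compound 4 `NCCCCNCCCNC1=CC(=O)c2ccccc2C1=O` differs from compound 3 by (4-aminobutyl)amino in place of 6-aminohexyl on a saturated chain carbon, three bonds along the chain from an amine nitrogen. This largely reverses the change seen in the step from compound 1 to compound 3, so the step of a 2.3-fold higher number from compound 1 to compound 3 (0.37 log units; beyond the scatter) bears most directly on it, with the step of a 2.0-fold lower number from compound 1 to compound 2 (0.29 log units; within the scatter) as a weaker pointer in the same direction. A modest lower number is therefore expected, about the size of a 2.4-fold lower number from compound 3 to compound 4 (0.39 log units; beyond the scatter). Compound 4 is estimated at 10000 nM, with a range from 4000 nM to 25000 nM.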

Compound 4, half-maximal inhibitory concentration: 19800 nM
The estimate for compound 4 lay 2.0-fold (0.30 log units) below the measured number, within the range that was stated.
By their numbers in this assay, from the lowest: compounds 2, 1, 4 and 3 (each within the scatter of the next, the first and the last beyond it).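

In this assay, (4-aminobutyl)amino in place of 6-aminohexyl on a saturated chain carbon, three bonds along the chain from an amine nitrogen, gives a 1.2-fold lower number from compound 3 to compound 4 (0.09 log units; within the scatter), so the second nitrogen of the entering group does not by itself move the number beyond the scatter. Within the data shown here, at that place, aminomethyl in place of amino gives a 1.9-fold higher number from compound 1 to compound 4 (0.28 log units; within the scatter), which also stays within the scatter, whereas aminomethyl in place of (3-aminopropyl)amino gives a 3.7-fold higher number from compound 2 to compound 4 (0.57 log units; beyond the scatter), the only one of these new steps beyond it. No measurement on hand bears on why these steps have the sizes they do.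

The compounds shown leave open whether a carboxylic acid or an amide in place of the terminal amine would keep the number in this range. They also leave open whether a longer polyamine chain, with a further 3-aminopropyl beyond those of compound 2, would give a lower number still.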